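Halogen swap on the triazole aryl: chloro to bromo

The source may report more compounds than this note shows. Statements on the series, on what has been measured and on what is new or still open speak of the compounds shown alone.

compound 1 `N#CC1=C(N)Oc2c(c3nc4ccccc4nc3c3ccccc23)C12C(=O)N(Cc1cnnn1-c1ccc(Cl)cc1)c1ccccc12` — > 50000 nM in an ADME assay on HUVEC cells (Homo sapiens) for antiproliferative activity, read by MTT assay, with a stated time of 48 h (on this read-out higher numbers stand for weaker inhibition and lower numbers for stronger inhibition), a limit
compound 2 `N#CC1=C(N)Oc2c(c3nc4ccccc4nc3c3ccccc23)C12C(=O)N(Cc1cnnn1-c1cccc(Cl)c1)c1ccccc12` — > 50000 nM in this assay, a limit

Compound 2 stands at the limit of this assay, a limit and not a number. Compound 1 likewise reports only a limit. The step that the two limits leave unreadable from compound 1 to compound 2 is therefore unreadable, as both values sit at the limit of > 50000 nM in this assay, at which 2 of the 2 values shown sit. Compound 3 `N#CC1=C(N)Oc2c(c3nc4ccccc4nc3c3ccccc23)C12C(=O)N(Cc1cnnn1-c1cccc(Br)c1)c1ccccc12` carries bromo in place of chloro on an aromatic carbon. Among the compounds with values here, no measured step bears on such a halogen swap, and the single recorded step gives no size. No step beyond the scatter is expected, and compound 3 is estimated at 100000 nM (range 30000 nM to 400000 nM), most likely again a limit, an expected step that the limit leaves unreadable from compound 2 to compound 3.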

Compound 3, half-maximal inhibitory concentration: > 50000 nM
Compound 3 ended at the assay's limit; the forecaster's own chance of this, stated with the estimate: 85%; the middle value lies beyond the limit too.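

Compound 3 gives > 50000 nM in this assay, a limit and not a number, so no step to compound 3 from compound 1 or compound 2 can be read: the limit of > 50000 nM in this assay, at which 3 of the 3 values shown sit.

Whether the identity or placing of the halogen on this aryl matters at all stays open: none of the compounds shown gives a readable number.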